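Carbamate ester variation on the shared core

A few compounds are considered here, and "the series" means these few. Any claim that something is new, unique, unknown or untested is made for them only; others in the source may bear on it.

Measured compounds:
compound 1, `CC(C)(C)OC(=O)N1CCC(O[C@H]2CC[C@H](Oc3cnc(S(C)(=O)=O)cn3)CC2)CC1` — 64 nM
compound 2, `C[C@@H](CF)OC(=O)N1CCC(O[C@H]2CC[C@H](Oc3cnc(S(C)(=O)=O)cn3)CC2)CC1` — 356 nM

In a functional assay on isolated protein for agonist activity at Glucose-dependent insulinotropic receptor (Rattus norvegicus), read by HTRF and cAMP accumulation (on this read-out higher numbers stand for an effect only at larger amounts of compound and lower numbers for an effect already at smaller amounts), compound 1 gives 64 nM and compound 2 gives 356 nM. Among the measured compounds shown here, compound 2 thus holds the highest of the two numbers in this assay; its nearest neighbour is compound 1, and the step of a 5.6-fold higher number from compound 1 to compound 2 (0.75 log units; beyond the scatter) lies beyond the scatter, the only change being 1-(fluoromethyl)ethyl in place of tert-butyl on an oxygen next to a carbonyl group.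

Compound 3, `CS(=O)(=O)c1cnc(O[C@H]2CC[C@H](OC3CCN(C(=O)OC4CCOC4)CC3)CC2)cn1`, is not yet measured in this assay. It differs from compound 2 by oxolan-3-yl in place of 1-(fluoromethyl)ethyl on an oxygen next to a carbonyl group. For the measured compounds named here, the one measured step that bears on this site is a 5.6-fold higher number from compound 1 to compound 2 (0.75 log units; beyond the scatter), which shows that replacing tert-butyl at this oxygen costs potency; no measured step shows a cyclic ether here, so the direction of the change from compound 2 to compound 3 cannot be read from the series. Given that the ester group again changes in size and shape at the same position, compound 3 is expected to land near compound 2, with the step of a 1.3-fold lower number from compound 2 to compound 3 (0.10 log units; within the scatter) estimated to stay within the scatter. The estimate for compound 3 in this assay is 280 nM, with a range from 80 nM to 900 nM.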

Compound 3, half-maximal effective concentration: 1500 nM
For compound 3 the middle estimate is 5.4-fold (0.73 log units) below the measured one; measured number above the stated range.
By their numbers in this assay, from the lowest: compound 1; then compound 2; then compound 3.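

Read in this assay, the loss on leaving tert-butyl does not stop at the open-chain 1-(fluoromethyl)ethyl group: oxolan-3-yl on the same oxygen next to the carbonyl group gives a 4.2-fold higher number from compound 2 to compound 3 (0.62 log units; beyond the scatter) and thus extends the drop beyond that first change. Against tert-butyl directly, the ring gives a 23-fold higher number from compound 1 to compound 3 (1.37 log units; beyond the scatter) as the largest step in the series, which places the three groups in the order tert-butyl, 1-(fluoromethyl)ethyl, oxolan-3-yl, with each step beyond the scatter and no compound going against that order. This position therefore tolerates neither replacement without loss, and the group that brings a five-membered ring with a hetero atom and a hydrogen-bond acceptor stands last, though no data at hand explain why.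

The compounds shown leave open whether the ring itself or its oxygen goes with the loss, a question that cyclopentyl on this oxygen would separate. Also open, from the compounds shown here alone, is whether the two mirror forms of oxolan-3-yl, which enters here without a defined stereocentre, read alike in this assay.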